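This account rests on a few compounds, and the source may have more. Where it says the series, first, only, none or still open, it means among the compounds named here.

Of the compounds shown here, three with a shared core have been measured in a functional assay on A549 cells (Homo sapiens) for antiproliferative activity, read by sulforhodamine B assay, with a stated time of 72 h; a higher number here means a weaker inhibitor, a lower number a stronger inhibitor. Compound 1 `COc1ncc(-c2ccc3ncnc(Nc4ccc(OCCO)cc4)c3c2)cc1NS(=O)(=O)c1ccc(F)cc1F` gives 2690 nM in this assay. Compound 2 `COc1ncc(-c2ccc3ncnc(Nc4ccc(OCCO)c(F)c4)c3c2)cc1NS(=O)(=O)c1ccc(F)cc1F`, which carries fluoro in place of hydrogen on an aromatic carbon, gives 6640 nM. Compound 3 `COC(=O)Cn1cc(Nc2ncnc3ccc(-c4cnc(OC)c(NS(=O)(=O)c5ccc(F)cc5F)c4)cc23)cn1` gives 4280 nM. Among these three numbers compound 3 stands second highest; its nearest neighbour is compound 2, and its steps to both compound 1 and compound 2 lie within the scatter, so no ordering among them can be claimed.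

Compound 4 `COc1ncc(-c2ccc3ncnc(Nc4ccc(OCCO)c(Cl)c4)c3c2)cc1NS(=O)(=O)c1ccc(F)cc1F` has not yet been measured. It differs from compound 3 by 3-chloro-4-(2-hydroxyethoxy)phenyl in place of 1-((methoxycarbonyl)methyl)-1H-pyrazol-4-yl on a nitrogen on an aromatic ring. Going by the values given here, two measured steps bear on this change. The exchange of the pyrazolyl group for the phenyl-type group was seen in a 1.6-fold higher number from compound 1 to compound 3 (0.20 log units; within the scatter) and in a 1.6-fold lower number from compound 2 to compound 3 (0.19 log units; within the scatter), both within the scatter. Among the compounds with values here, the only step involving a halogen on that ring is a 2.5-fold higher number from compound 1 to compound 2 (0.39 log units; beyond the scatter), a modest step beyond the scatter. Within the data shown here, compound 4 carries chloro where compound 2 carries fluoro, and no step for that exchange has been measured.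

The expectation for compound 4 in this assay is therefore a step in the direction of a higher number, a 1.8-fold higher number from compound 3 to compound 4 (0.24 log units; within the scatter), of about the size seen between compound 3 and compound 2 or somewhat larger. Compound 4 is expected to give 7500 nM, with a range from 3000 nM to 19000 nM.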

Compound 4, half-maximal inhibitory concentration: 5980 nM
Compound 4: the middle estimate sits 1.3-fold (0.10 log units) above what was measured; measured number inside the range.
By their numbers in this assay, from the lowest: compounds 1, 3, 4 and 2 (each within the scatter of the next, the first and the last beyond it).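

For the chloro group, this assay shows a 2.2-fold higher number from compound 1 to compound 4 (0.35 log units; beyond the scatter), and this second halogen step points the same way as the earlier 2.5-fold higher number from compound 1 to compound 2 (0.39 log units; beyond the scatter), so the rise beyond the scatter no longer rests on fluoro alone, and neither halogen compound goes against it. The two halogens cannot be told apart at this place, since chloro in place of fluoro on an aromatic carbon gives a 1.1-fold lower number from compound 2 to compound 4 (0.05 log units; within the scatter), while the exchange on the nitrogen gives a 1.4-fold higher number from compound 3 to compound 4 (0.15 log units; within the scatter), which leaves 3-chloro-4-(2-hydroxyethoxy)phenyl and 1-((methoxycarbonyl)methyl)-1H-pyrazol-4-yl without a readable order. Nothing available here accounts for these steps.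

The compounds shown leave open whether the rise belongs to halogens alone or would also follow a methyl or methoxy group on that aromatic carbon. They also leave open whether a carboxylic acid in place of the methyl ester on the pyrazolyl group, or an amine in place of the hydroxyl group on the 2-hydroxyethoxy chain, would give a step beyond the scatter.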